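A few compounds are considered here, and "the series" means these few. Any claim that something is new, unique, unknown or untested is made for them only; others in the source may bear on it.

Measured in a functional assay on HCT-116 cells (Homo sapiens) for inhibition, read by luminescence and resazurin assay, with a stated time of 3 days; a lower number here means a stronger inhibitor, a higher number a weaker inhibitor:
- compound 1 `CCCNc1nc(NCc2ccc(C(=O)NCc3ccc(F)cc3)cc2)c2cc(C)ccc2n1`: 4400 nM
- compound 2 `CCCNc1nc(NCc2ccc(C(=O)Nc3ccc(F)cc3)cc2)c2ccccc2n1`: 1500 nM
- compound 3 `CCCNc1nc(NCc2ccc(C(=O)Nc3ccc(Cl)nc3)cc2)c2cc(C)ccc2n1`: 1500 nM

Compound 3 stands level with compound 2 at the digits given, the two together at the low end of the three numbers; compound 1 sits furthest away, its number higher by a 2.9-fold lower number from compound 1 to compound 3 (0.47 log units; beyond the scatter) read in reverse, a modest step beyond the scatter.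

Compound 4 `CCCNc1nc(NCc2ccc(C(=O)Nc3ccc(F)cc3)cc2)c2cc(C)ccc2n1` is the next member, not yet measured in this assay. The change from compound 3 is 4-fluorophenyl in place of 6-chloropyridin-3-yl on an amide-type nitrogen. Among the compounds with values here, the one measured step that bears on it is a 2.9-fold lower number from compound 1 to compound 3 (0.47 log units; beyond the scatter), where the 6-chloropyridin-3-yl group arrived in place of 4-fluorobenzyl and the number fell modestly; here the chloropyridinyl group leaves again, but what enters is 4-fluorophenyl, not the benzyl. Compound 2 already carries the (4-fluorophenyl)carbamoyl piece and differs from compound 4 only in the core; in this assay compound 2 gives 1500 nM, no different from compound 3 at the digits given. The expectation is therefore a step of a 1.1-fold higher number from compound 3 to compound 4 (0.05 log units; within the scatter), that is, nothing beyond the scatter. Compound 4 is estimated at 1700 nM, with a range from 700 nM to 4000 nM.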

Compound 4, half-maximal inhibitory concentration: 1200 nM
Estimate against measurement, compound 4: 1.4-fold (0.15 log units) above; low and high end bracket the measured number.
By their numbers in this assay, from the lowest: compounds 4, 2 and 3 (each within the scatter of the next); then compound 1.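

Working from this assay, replacing 6-chloropyridin-3-yl with 4-fluorophenyl on the amide-type nitrogen (a 1.3-fold lower number from compound 3 to compound 4 (0.10 log units; within the scatter)) does not separate the two groups, even though the ring nitrogen and chlorine are exchanged for carbon and fluorine. Methyl in place of hydrogen on an aromatic carbon, seen here for the first time as a single change, also leaves the number within the scatter (a 1.3-fold lower number from compound 2 to compound 4 (0.10 log units; within the scatter)). The direct comparison of the two fluorinated groups (a 3.7-fold lower number from compound 1 to compound 4 (0.56 log units; beyond the scatter)) matches the earlier chloropyridinyl step (a 2.9-fold lower number from compound 1 to compound 3 (0.47 log units; beyond the scatter)): with the methyl-bearing core, both groups with the ring set directly on the amide-type nitrogen give lower numbers than 4-fluorobenzyl, and no compound shown goes against this.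

These compounds leave open how the number responds to a carboxylic acid or a nitrile on that ring, and to a longer chain or a morpholine in place of the propylamino group. No measurement at hand accounts for any of these steps.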